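Ethoxycarbonyl for cyano in a series of limits

The compounds below may be only part of what the source reports. "The series", "measured", "known", "first", "only" and "open" are said of these compounds alone.

Compound 1 (`N#Cc1ccc(NCc2cncn2Cc2ccc(-c3ccccc3)cc2)cc1-c1ccccc1`) gives > 1000 nM in a toxicity assay on NIH3T3 cells (Mus musculus) for cytotoxicity, read by resazurin assay (on this read-out lower numbers stand for an effect already at smaller amounts and higher numbers for an effect only at larger amounts of compound), as a limit and not a number. Compound 2 (`N#Cc1ccc(NCc2cncn2Cc2ccc(-c3ccccc3)cc2N)cc1-c1ccccc1`) gives > 1000 nM in this assay as a limit too. Compound 3 (`COC(=O)c1ccc(NCc2cncn2Cc2ccc([N+](=O)[O-])cc2)cc1-c1ccccc1`), which carries methoxycarbonyl, gives > 10000 nM in this assay as a limit as well. Among the measured compounds shown here, compound 1 therefore has no numeric standing, and the series so far holds only limits.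

The next change leads to compound 4 (`CCOC(=O)c1ccc(NCc2cncn2Cc2ccc(-c3ccccc3)cc2)cc1-c1ccccc1`), with ethoxycarbonyl in place of cyano on an aromatic carbon. For the measured compounds named here, the one measured step (a step that the two limits leave unreadable from compound 1 to compound 2) has no readable size and concerns amino in place of hydrogen, so it sets no size here. The closest guide to the entering group is the limit of compound 3 (> 10000 nM) in this assay. The expected step (a step that the limit leaves unreadable from compound 1 to compound 4) is estimated to point toward higher numbers, if it is readable at all. For compound 4 the estimated value is 5000 nM with an expected range from 1000 nM to 20000 nM and a report of only a limit is likely.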

Compound 4, half-maximal effective concentration: > 10000 nM
Compound 4: a limit, no number; the forecaster's own chance of this, stated with the estimate: 80%; at least 2.0-fold (0.30 log units) between middle value and limit.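

Compound 1 and compound 4 both stand as limits and not as numbers, so no step can be read between them. The compounds shown leave open whether ethoxycarbonyl in place of cyano on an aromatic carbon shifts the read-out at all, and at what concentration any of these compounds would reach a half-maximal effect.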